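Fluorine count and lipophilicity in short fluorinated alcohols

The source may report more compounds than this note shows. Statements on the series, on what has been measured and on what is new or still open speak of the compounds shown alone.

compound 1, `OCCC(F)CC(F)(F)F`, gives 0.84 in a physicochemical assay for lipophilicity, read by NMR; on this read-out higher numbers stand for higher lipophilicity and lower numbers for lower lipophilicity
compound 2, `OCCC(F)(F)CC(F)(F)F`, gives 1.12 in this assay
compound 3, `OCCCC(F)(F)CF`, gives 0.58 in this assay

Compound 1 and compound 2 differ in one place: fluoro in place of hydrogen on a saturated chain carbon bound to a fluorine atom and two saturated chain carbons. On this change the reading moved by a number 0.28 log units higher from compound 1 to compound 2 (within the scatter). Compound 3 and compound 1 lie within the scatter of each other in this assay, while compound 2 lies beyond the scatter from compound 3. How the core of compound 3 differs from the core of compound 1 is not broken down here.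

Compound 4, `OCCCC(F)(F)C(F)F`, has not yet been measured in this assay. It differs from compound 3 by fluoro in place of hydrogen on a saturated chain carbon bound to a fluorine atom and a saturated chain carbon. Within the data shown here, this is the same kind of change as the one from compound 1 to compound 2, but not the same: there the carbon taking the new fluorine was bound to a fluorine atom and two saturated chain carbons, here it is bound to a fluorine atom and a saturated chain carbon, and cut one bond further out the change reads fluoromethyl to difluoromethyl.

The step from compound 3 to compound 4 in this assay is expected to be a number 0.30 log units higher from compound 3 to compound 4 (within the scatter), set beside the measured one. This expectation rests only on compound 1 and compound 2, where the same kind of change gave a number 0.28 log units higher from compound 1 to compound 2 (within the scatter). Compound 4 is therefore expected to give 0.88 in this assay, with a range from 0.6 to 1.15.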

Compound 4, partition coefficient: 0.97
Estimate against measurement, compound 4: 0.09 log units below, and the stated range covers the measured number.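

In this assay, the change from fluoromethyl to difluoromethyl on the core of compound 3 comes out as a number 0.39 log units higher from compound 3 to compound 4 (beyond the scatter), whereas the same kind of change on the core of compound 1, where the carbon taking the new fluorine is bound to a fluorine atom and two saturated chain carbons, reads a number 0.28 log units higher from compound 1 to compound 2 (within the scatter). Among these compounds, the series therefore offers one pair on each of two cores, and only the pair on the core of compound 3 gives a step that clears the scatter, so the change is established beyond the scatter on that core alone and no size can yet be said to carry from one core to the other. Nothing available here bears on why either step came out as it did.

All four compounds shown are short fluorinated alcohols, which leaves open how the same change would read on a longer chain, or with an amine or a carboxylic acid in place of the alcohol. As far as these compounds go, it also remains open whether a further pair on either core would give a step of similar size, since each core is represented here by a single pair.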